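The source may report more compounds than this note shows. Statements on the series, on what has been measured and on what is new or still open speak of the compounds shown alone.

Of the compounds shown here, three built on a shared core have been measured in a functional assay on the whole organism (aorta) with Rattus norvegicus as the target; on this read-out higher numbers stand for larger maximal responses and lower numbers for smaller maximal responses. Compound 1 `C/N=C(/S)C1=CC(C)(C)Oc2ccc([N+](=O)[O-])cc21` gives 63.5%, compound 2 `CNC(=O)C1=CC(C)(C)Oc2ccc([N+](=O)[O-])cc21` gives 61%, and compound 3 `CC1(C)C=C(/C(S)=N\CCC#N)c2cc([N+](=O)[O-])ccc2O1` gives 78.5%. Compound 3 stands highest of the three on these numbers, the gaps being a number 15 percentage points higher from compound 1 to compound 3 (beyond the scatter) and a number 17.5 percentage points higher from compound 2 to compound 3 (beyond the scatter), both beyond the scatter. Compound 4 `CC1(C)C=C(C(=O)NCCC#N)c2cc([N+](=O)[O-])ccc2O1` has not yet been measured. It differs from compound 3 in one place: a group of 7 heavy atoms (4 carbon, 2 nitrogen, 1 oxygen; no ring) in place of a group of 7 heavy atoms (4 carbon, 2 nitrogen, 1 sulfur; no ring), on a double-bonded ring carbon. Among the measured compounds shown here, one measured step bears on this change, the exchange of the same sulfur-bearing group for an oxygen-bearing group on the same ring carbon, which gave a number 2.5 percentage points lower from compound 1 to compound 2 (within the scatter), a change within the scatter. On that basis no step beyond the scatter is expected in this assay, and the estimated step is a number 2.5 percentage points lower from compound 3 to compound 4 (within the scatter). Compound 4 is therefore expected to give about 76% in this assay, with a likely range from 62% to 88%.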

Compound 4, intrinsic activity: the largest response reached, in percent of the reference agonist's: 73.1%
The estimate for compound 4 lay 2.9 percentage points above the measured number, and the stated range covers the measured number.
By their numbers in this assay, from the lowest: compounds 2, 1, 4 and 3 (each within the scatter of the next, the first and the last beyond it).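

The exchange of sulfur for oxygen, first seen on the small N-methyl group, gives a number 5.4 percentage points lower from compound 3 to compound 4 (within the scatter) in this assay when the chain carries a nitrile, so at this position on the double-bonded ring carbon the two forms cannot be told apart with either chain. Cyanomethyl on the chain, so far seen only with the sulfur-bearing group, also gives a number 12.1 percentage points higher from compound 2 to compound 4 (beyond the scatter) with the amide-type nitrogen, and it does so to a like degree: the same change on two cores in this assay, a number 15 percentage points higher (beyond the scatter) from compound 1 to compound 3 and a number 12.1 percentage points higher (beyond the scatter) from compound 2 to compound 4, 2.9 percentage points apart, within the scatter of two such steps Both changes taken together give a number 9.6 percentage points higher from compound 1 to compound 4 (within the scatter), which does not clear the scatter.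

The compounds shown leave open whether a plain propyl group on that nitrogen would give the same step as the 2-cyanoethyl chain. They also leave open how a longer chain, or a chain ending in an amine or a carboxylic acid, would read here.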